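Nitrophenyl for methoxyphenyl ester swap across two cores

The source may hold more compounds than are shown below. What is called first, only, known or untested is meant among the compounds shown, and "the series" means these compounds.

Measured compounds:
Compound 1, `COc1cccc(C(=O)Oc2cc3c(cc2C)[C@@H](C(C)C)CC=C3C)c1`: 11.9%
Compound 2, `CC1=CC[C@H](C(C)C)c2cc(C)c(OC(=O)c3ccc([N+](=O)[O-])cc3)cc21`: 72.9%
Compound 3, `COc1cccc(C(=O)Oc2cc3c(C)ccc(C(C)C)c3cc2C)c1`: 31.8%

All three were tested in a functional assay on MCF7 cells (Homo sapiens) for antiproliferative activity, read by sulforhodamine B assay, with a stated time of 48 h, tested at 50 uM; a higher number here means more inhibition at the concentration tested (going by the name of the read-out), a lower number less inhibition. Compound 1 and compound 2 share one core and differ only in the ester aryl group; the change is 4-nitrophenyl in place of 3-methoxyphenyl on a carbonyl carbon, and the step it made is a number 61 percentage points higher from compound 1 to compound 2 (beyond the scatter). Compound 3 carries a different core; how the core of compound 3 differs from the core of compound 1 is not broken down here, and on their own numbers compound 3 sits above compound 1 in this assay, beyond the scatter, and below compound 2.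

Compound 4, `Cc1cc2c(C(C)C)ccc(C)c2cc1OC(=O)c1ccc([N+](=O)[O-])cc1`, is not yet measured. It stands to compound 3 as compound 2 stands to compound 1: the change is 4-nitrophenyl in place of 3-methoxyphenyl on a carbonyl carbon. The place is the same in both pairs, so this is the same change made on a second core.

Within the data shown here, the only guide is the one measured step, and it is large. A step from compound 3 to compound 4 of about a number 48.2 percentage points higher from compound 3 to compound 4 (beyond the scatter) is expected, somewhat smaller than the measured one because compound 3 already starts at 31.8%, a higher number than compound 1 has, which leaves less room for the number to rise. Compound 4 is therefore estimated at 80% in this assay. The expected range for compound 4 runs from 55% to 97%, the width reflecting that a single pair cannot show whether the step carries over unchanged to a different core.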

Compound 4, a percentage reported as inhibition, at one concentration (the size of the read-out at that concentration, not a potency): 100%
Compound 4: middle estimate off by 20 percentage points, on the low side; the whole stated range lies below it.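

On the second core, 4-nitrophenyl in place of 3-methoxyphenyl on a carbonyl carbon gives, in this assay, a number 68.2 percentage points higher from compound 3 to compound 4 (beyond the scatter). Set beside the step on the first core, the change carries over between these two cores with no difference that can be told apart: the same change on two cores in this assay, a number 61 percentage points higher (beyond the scatter) from compound 1 to compound 2 and a number 68.2 percentage points higher (beyond the scatter) from compound 3 to compound 4, 7.2 percentage points apart, within the scatter of two such steps. This rests on one pair per core at a single concentration, so it describes the size of the read-out and not a potency; with compound 4 at 100%, the top of a percentage scale, the full size of the step on this core may be hidden, and nothing here speaks for any further core.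

From the compounds shown here alone, with only these two aryl groups on the ester, it remains open whether the rise follows from gaining the nitro group, from its place on the ring, or from losing the methoxy group, a question that esters carrying 3-nitrophenyl, 4-methoxyphenyl or plain phenyl could separate. Also open, going by these compounds, is how much depends on the ester link itself, which an amide link would test, and whether a 4-aminophenyl or 4-carboxyphenyl group would give a comparable step on either core.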